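The compounds below may be only part of what the source reports. "The series", "measured", "known", "first", "only" and "open" are said of these compounds alone.

In a functional assay on cells (KATO III cell, Homo sapiens) for antiproliferative activity, read by MTT assay (on this read-out lower numbers stand for stronger inhibition and higher numbers for weaker inhibition), compound 1 `O=C1NC(c2ccccc2)CN1S(=O)(=O)c1ccc2c(c1)CCCN2` gives only a limit of the assay, > 20000 nM. Within the data shown here, compound 2 `O=C(OCCCl)N1CCCc2cc(S(=O)(=O)N3CC(c4ccccc4)NC3=O)ccc21` reads 8680 nM, and compound 3 `O=C(CCl)N1CCCc2cc(S(=O)(=O)N3CC(c4ccccc4)NC3=O)ccc21` reads 3460 nM, the lowest actual number so far. Compound 4 `NC(=O)N1CCCc2cc(S(=O)(=O)N3CC(c4ccccc4)NC3=O)ccc21` differs from compound 3 by one swap: amino in place of chloromethyl on a carbonyl carbon. Among the measured compounds shown here, three measured steps bear on it: an at least 5.7-fold lower number from compound 1 to compound 3 (0.76 log units; beyond the scatter), an at least 2.3-fold lower number from compound 1 to compound 2 (0.36 log units; beyond the scatter) and a 2.5-fold lower number from compound 2 to compound 3 (0.40 log units; beyond the scatter). All are modest or at least modest, and the last shows that the group on this carbonyl carbon can move the number. A modest rise in this assay, meaning weaker inhibition, is therefore expected. The expected step is a 3.2-fold higher number from compound 3 to compound 4 (0.50 log units; beyond the scatter). For compound 4 the estimated value is 11000 nM, within an expected range of 5000 nM to 25000 nM.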

Compound 4, half-maximal inhibitory concentration: 3590 nM
Compound 4: the middle estimate sits 3.1-fold (0.49 log units) above what was measured; measured number below the stated range.
By their numbers in this assay, from the lowest: compounds 3 and 4 (each within the scatter of the next); then compound 2. At a limit, above all of these: compound 1.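

Putting amino in place of chloromethyl on this carbonyl carbon leaves the number in this assay within the scatter (a 1.0-fold higher number from compound 3 to compound 4 (0.02 log units; within the scatter)), so among these compounds the chlorine-bearing group is not required for this level of inhibition. Amino also gives a lower number than 2-chloroethoxy at the same place (a 2.4-fold lower number from compound 2 to compound 4 (0.38 log units; beyond the scatter)). Carbamoyl in place of hydrogen on the nitrogen gives (an at least 5.5-fold lower number from compound 1 to compound 4 (0.74 log units; beyond the scatter)), but that step is only a bound, since compound 1 stands at a limit: the limit of > 20000 nM in this assay, at which 1 of the 4 values shown sits.

From the compounds shown here alone, whether a dimethylamino group or a longer chain on this carbonyl carbon would shift the number remains open. So does whether any group here can give a much lower number.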